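Arylpyrazole diazepane and piperazine series: 5-HT1E binding

The compounds below may be only part of what the source reports. "The series", "measured", "known", "first", "only" and "open" are said of these compounds alone.

Measured compounds:
compound 1 `Clc1ccc(-c2n[nH]cc2N2CCCNCC2)cc1`, > 10000 nM
compound 2 `Fc1ccc(-c2n[nH]cc2N2CCCNCC2)cc1`, > 10000 nM
compound 3 `Clc1ccc(-c2n[nH]cc2N2CCNCC2)cc1`, > 10000 nM

In an assay on isolated protein for binding affinity to 5-hydroxytryptamine receptor 1E (Homo sapiens) (on this read-out higher numbers stand for weaker inhibition and lower numbers for stronger inhibition), compound 1 gives only a limit of the assay, > 10000 nM. Compound 2 likewise gives only a limit, > 10000 nM. Compound 3 also gives only a limit, > 10000 nM. The change fluoro in place of chloro on an aromatic carbon gives a step that the two limits leave unreadable from compound 1 to compound 2, because all three values sit at the limit of > 10000 nM in this assay, at which 3 of the 3 values shown sit. The difference between the two cores of compound 1 and compound 3 is not broken down here. Compound 4 `Fc1ccc(-c2n[nH]cc2N2CCNCC2)cc1` is not yet measured; it carries the same change as before, (fluoro in place of chloro on an aromatic carbon). For this assay the expected step is a step that the limit leaves unreadable from compound 3 to compound 4, resting on compound 3 at > 10000 nM and on the earlier step being unreadable. Compound 4 is therefore estimated at 20000 nM, most likely again only a limit.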

Compound 4, inhibition constant: > 10000 nM
Compound 4 gave a limit, no number; the forecaster's own chance of this, stated with the estimate: 90%; the middle value is on the limit's open side.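

No step can be read from compound 3 to compound 4, because both stay at a limit: (the limit of > 10000 nM in this assay, at which 4 of the 4 values shown sit). In this assay the compounds shown leave open how fluoro and chloro, or the two cores, compare.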